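Swapping the amine substituent on the para-positioned aryl amide

This account rests on a few compounds, and the source may have more. Where it says the series, first, only, none or still open, it means among the compounds named here.

Measured compounds:
- compound 1, `CN(C)CCN(CCN(C)C)c1ccc(C(=O)N2CCc3ccc(OS(N)(=O)=O)cc3C2)cc1`: 3.8%
- compound 2, `NS(=O)(=O)Oc1ccc2c(c1)CN(C(=O)c1cccc(N(Cc3ccccc3)Cc3ccco3)c1)CC2`: 27.5%
- compound 3, `CN(C)CCCN(Cc1ccccc1)c1cccc(C(=O)N2CCc3ccc(OS(N)(=O)=O)cc3C2)c1`: 23.8%

In an assay on HEK293 cells for inhibition of Steryl-sulfatase (Homo sapiens), tested at 0.1 uM (a higher number here means a stronger effect of the compound at the concentration tested, a lower number a weaker effect), compound 1 gives 3.8%, the lowest of the three numbers; compound 3 and compound 2 lie beyond the scatter above it. Compound 4, `CCN(Cc1ccccn1)c1ccc(C(=O)N2CCc3ccc(OS(N)(=O)=O)cc3C2)cc1`, differs from compound 1 by ethyl((pyridin-2-yl)methyl)amino in place of bis(2-(dimethylamino)ethyl)amino on an aromatic carbon. Among the measured compounds shown here, the only measured step, a number 3.7 percentage points lower from compound 2 to compound 3 (within the scatter), lies within the scatter and concerns a different position and a different pair of groups, so it says little about this change. What the data show is that the two compounds carrying an aromatic ring on the amine nitrogen, compound 2 and compound 3, sit above compound 1. Compound 4 also carries such a ring, so its value is expected to rise by a number 11.2 percentage points higher from compound 1 to compound 4 (beyond the scatter), reaching an estimated 15% (range 3% to 30%).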

Compound 4, a percentage reported as inhibition, at one concentration (the size of the read-out at that concentration, not a potency): 42.5%
The estimate for compound 4 lay 27.5 percentage points below the measured number; the whole stated range lies below it.
By their numbers in this assay, from the lowest: compound 1; then compounds 3 and 2 (each within the scatter of the next); then compound 4.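

Putting ethyl((pyridin-2-yl)methyl)amino in place of bis(2-(dimethylamino)ethyl)amino gives a number 38.7 percentage points higher from compound 1 to compound 4 (beyond the scatter) and so shows that the read-out at this position responds strongly to the choice of amine substituent. The swap replaces two open chains with an ethyl group and a group holding one six-membered aromatic ring, so several features change at once. Nothing measured here explains the rise. 

The compounds shown do not reveal whether the ring, its nitrogen or the ethyl group matters most. Nor do they show how a pyridin-3-yl ring or a morpholine ring would fare on this aromatic carbon.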